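This account rests on a few compounds, and the source may have more. Where it says the series, first, only, none or still open, it means among the compounds named here.

Three compounds of the series carry a number in a functional assay on the whole organism (strain CF) for inhibition, with Mus musculus as the target, at a dose of 25 mg/kg by the oral route; a lower number here means less inhibition, a higher number more inhibition at the dose given (going by the name of the read-out). Compound 1 `CC1(C)CC(=O)C2=C(C1)N(c1ccccc1)N=C(c1ccccc1)C2` gives 26% there, level with compound 3 `CC1(C)CC(=O)C2=C(C1)N(CCN1CCNCC1)N=C(c1ccc(F)cc1)C2`, which gives 26%; these two stand together as the lowest of the three numbers. Furthest from compound 1 lies compound 2 `CCOC(=O)NNC1=C(CC(=O)c2ccccc2)C(=O)CC(C)(C)C1` with 51%, a gap beyond the usual scatter. Compound 4 `CC1(C)CC(=O)C2=C(C1)NN=C(c1ccccc1)C2` has no number yet and differs from compound 1 in one place: hydrogen in place of phenyl on an amine nitrogen in a ring. Within the data shown here, no measured pair shows this change, so its effect is unknown. The expectation for compound 4 is a step of no change at the digits printed from compound 1 to compound 4 (within the scatter) that stays within the scatter. In this assay compound 4 is estimated at 26%, with a range from 8% to 45%.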

Compound 4, a percentage reported as inhibition, in the whole organism at one dose (the size of the read-out at that dose, not a potency): 26%
Estimate against measurement, compound 4: no gap at the digits printed; low and high end bracket the measured number.
By their numbers in this assay, from the lowest: compounds 1, 3 and 4 (each within the scatter of the next); then compound 2.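

Hydrogen in place of phenyl on the amine nitrogen in a ring gives no change at the digits printed from compound 1 to compound 4 (within the scatter) in this assay. Among these compounds, this is the first measured pair at this position, and at this dose the read-out holds with or without the phenyl group on that nitrogen. No measurement on hand explains the flat step.

On these data alone, whether methyl or a longer chain ending in a carboxylic acid on this nitrogen would move the number stays open. With a single dose, the pair also leaves open whether the two compounds would stay level at other doses.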